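Swapping a Naphthyloxymethyl Arm for Plain Phenyl

A few compounds are considered here, and "the series" means these few. Any claim that something is new, unique, unknown or untested is made for them only; others in the source may bear on it.

Compound 1 `CCn1cc(-c2nnc(COc3ccc4ccccc4c3)o2)c(=O)c2cc(F)c(N3CCNCC3)cc21`: 80.2 ug/mL
Compound 2 `O=c1c(-c2nnc(COc3ccc4ccccc4c3)o2)cn(C2CC2)c2cc(N3CCNCC3)c(F)cc12`: 16 ug/mL
Compound 3 `O=c1c(-c2nnc(-c3ccc(Nc4ccccc4)cc3)o2)cn(C2CC2)c2cc(N3CCNCC3)c(F)cc12`: 52 ug/mL

These three compounds were tested in a functional assay on A549 cells (Homo sapiens) for cytotoxicity, read by MTT assay; on this read-out higher numbers stand for weaker inhibition and lower numbers for stronger inhibition. Compound 1 shows the highest number of the three; compound 3 sits close to it, and the two values lie within the usual scatter of each other, while compound 2 gives a clearly lower number. Going by the values given here, the only step between compounds that differ in a single place is a 5.0-fold lower number from compound 1 to compound 2 (0.70 log units; beyond the scatter), and it concerns the group on the aromatic nitrogen, not the part changed here.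

Compound 4 `CCn1cc(-c2nnc(-c3ccccc3)o2)c(=O)c2cc(F)c(N3CCNCC3)cc21` is compound 1 with phenyl in place of ((naphthalen-2-yl)oxy)methyl on an aromatic carbon. Among the compounds with values here, no measured pair tests this change on its own. Compounds 2 and 3 both carry cyclopropyl and differ in the group on the five-membered aromatic ring with 2 nitrogen and 1 oxygen; compound 2 gives 16 ug/mL and compound 3 gives 52 ug/mL, so the member with an aryl group directly on that ring shows the higher number, though the two groups differ in more than one way. With that thin support, compound 4 is expected to give a number similar to or somewhat higher than its parent, a 1.4-fold higher number from compound 1 to compound 4 (0.14 log units; within the scatter), with wide uncertainty. The estimate for compound 4 in this assay is 110 ug/mL, between 45 ug/mL and 250 ug/mL.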

Compound 4, half-maximal inhibitory concentration: 112 ug/mL
Beside the measured number, compound 4's estimate is 1.0-fold (0.01 log units) below it; the measured number falls inside the stated range.
By their numbers in this assay, from the lowest: compound 2; then compounds 3, 1 and 4 (each within the scatter of the next, the first and the last beyond it).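

In this assay, the direct test of this position gives a 1.4-fold higher number from compound 1 to compound 4 (0.15 log units; within the scatter), so the result for compound 4 cannot be told apart from that for compound 1. On the core that carries ethyl, the aromatic carbon next to the ring nitrogen and the ring oxygen can therefore go from ((naphthalen-2-yl)oxy)methyl, with 12 heavy atoms, to phenyl, with 6 heavy atoms, with no change that this read-out can resolve. No supporting measurement is available to explain why this exchange leaves the number within the scatter.

Going by these compounds alone, the pair covers only one core and two groups, so it remains open whether the same holds with cyclopropyl on the aromatic nitrogen, the change that gave a 5.0-fold lower number from compound 1 to compound 2 (0.70 log units; beyond the scatter) with the ((naphthalen-2-yl)oxy)methyl group in place. It also leaves open how this carbon would respond to something quite different from these aromatic groups, such as a plain methyl, an aminomethyl group or a carboxylic acid.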